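Three Analogues Measured, a Fourth Awaits Its Number

The source may hold more compounds than are shown below. What is called first, only, known or untested is meant among the compounds shown, and "the series" means these compounds.

Three compounds share one core and differ only in the group carried on an amine nitrogen in a ring. Compound 1 `Nc1scc(CN2CCN(c3ccc(Cl)cc3Cl)CC2)c1C(=O)c1ccc(Cl)cc1` gives -74% in a functional assay on CHO cells with adenosine receptor A1 (Homo sapiens) as the target, read by cAMP accumulation and immunoassay, with a stated time of 6 min, tested at 10 uM; on this read-out higher numbers stand for a weaker effect at the one concentration tested and lower numbers for a stronger effect. Compound 2 `Nc1scc(CN2CCN(c3cccc(Cl)c3Cl)CC2)c1C(=O)c1ccc(Cl)cc1` gives -77% in this assay, and compound 3 `Nc1scc(CN2CCN(c3ccc(Cl)cc3F)CC2)c1C(=O)c1ccc(Cl)cc1` gives -81% in this assay. Among these three numbers compound 2 stands second highest: its nearest neighbour is compound 1, with a number 3 percentage points lower from compound 1 to compound 2 (within the scatter), and its furthest is compound 3, with a number 4 percentage points lower from compound 2 to compound 3 (within the scatter). Between the other two there is a number 7 percentage points lower from compound 1 to compound 3 (within the scatter).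

Compound 4 `Nc1scc(CN2CCN(c3ccc(Cl)c(C(F)(F)F)c3)CC2)c1C(=O)c1ccc(Cl)cc1` has not yet been measured. It differs from compound 2 in one place: 4-chloro-3-(trifluoromethyl)phenyl in place of 2,3-dichlorophenyl on an amine nitrogen in a ring. Among the compounds with values here, the steps that bear on this exchange are those that replace the same group on the same ring nitrogen, a number 3 percentage points lower from compound 1 to compound 2 (within the scatter) and a number 4 percentage points lower from compound 2 to compound 3 (within the scatter), and neither moved beyond the scatter. The account therefore expects no step beyond the scatter in this assay, that is no change at the digits printed from compound 2 to compound 4 (within the scatter). For compound 4 the estimated value is -77%, with an expected range from -90% to -62%.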

Compound 4, a percentage reported as activity, at one concentration (the size of the read-out at that concentration, not a potency): -60%
Compound 4: the middle estimate sits 17 percentage points below what was measured, outside the stated range (above it).
By their numbers in this assay, from the lowest: compounds 3, 2 and 1 (each within the scatter of the next); then compound 4.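

Up to this point, each exchange of the group on the amine nitrogen in a ring had moved the number in this assay by no more than the scatter, so the position looked tolerant of change. The 4-chloro-3-(trifluoromethyl)phenyl group ends that picture, with a number 17 percentage points higher from compound 2 to compound 4 (beyond the scatter) and a number 21 percentage points higher from compound 3 to compound 4 (beyond the scatter) and also a number 14 percentage points higher from compound 1 to compound 4 (beyond the scatter) so that the effect at the one concentration tested is weaker against all three earlier compounds. Nothing measured here speaks to what lies behind this shift.

With only this one such group shown, the part played by the trifluoromethyl group cannot be separated from that of the whole 4-chloro-3-(trifluoromethyl)phenyl exchange. Going by these compounds, whether a methyl group or a nitrile in its place would give a step of the same size remains open.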